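Working notes: clearance from compound 2 to compound 3

A few compounds are considered here, and "the series" means these few. Any claim that something is new, unique, unknown or untested is made for them only; others in the source may bear on it.

Measured in an ADME assay on microsomes from liver (Mus musculus) for metabolic stability; a higher number here means faster removal of the compound, a lower number slower removal:
- compound 1 `Cc1n[nH]c(-c2ncc3c(N4CCCCS4(=O)=O)ccnc3c2O)n1`: 0.6 mL.min-1.g-1
- compound 2 `Cc1n[nH]c(-c2ncc3c(-c4ccccc4)ccnc3c2O)n1`: 9.4 mL.min-1.g-1

Compound 2 holds the higher of the two numbers. Compound 3 `Cc1n[nH]c(-c2ncc3c(-c4ccccc4C(F)(F)F)ccnc3c2O)n1` differs from it by trifluoromethyl in place of hydrogen on an aromatic carbon, ortho to a large group. Among the measured compounds shown here, only one measured step bears on this, a 16-fold higher number from compound 1 to compound 2 (1.19 log units; beyond the scatter). That step is large, but it exchanges one whole group for another, so it is a loose guide to this smaller change. In this assay, a slight rise is expected, with the estimated step of a 1.3-fold higher number from compound 2 to compound 3 (0.11 log units; within the scatter) staying within the scatter. Compound 3 is estimated at 12 mL.min-1.g-1, with an expected range of 5 mL.min-1.g-1 to 28 mL.min-1.g-1.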

Compound 3, intrinsic clearance in microsomes: 1.4 mL.min-1.g-1
Beside the measured number, compound 3's estimate is 8.6-fold (0.93 log units) above it; measured number below the stated range.
By their numbers in this assay, from the lowest: compound 1; then compound 3; then compound 2.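

In this assay, trifluoromethyl in place of hydrogen on an aromatic carbon, ortho to a large group, gives a 6.7-fold lower number from compound 2 to compound 3 (0.83 log units; beyond the scatter). The earlier step exchanged one whole group for another, whereas this one shows that a single substitution, with the six-membered aromatic ring of carbon only kept, moves the number beyond the scatter. No measurement shown accounts for this change.

Still open, from the compounds shown here alone, is whether the change belongs to trifluoromethyl itself or would also follow from methyl or chlorine at this place. Going by these compounds, how an amine or a carboxylic acid there would read in this assay also remains open.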